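The source may hold more compounds than are shown below. What is called first, only, known or untested is meant among the compounds shown, and "the series" means these compounds.

Three compounds have been measured in a functional assay, read by spectrophotometry, with a stated time of 2 h, tested at 0.5 mg/mL; a higher number here means a stronger effect of the compound at the concentration tested, a lower number a weaker effect:

compound 1 `CC(C)[C@@H]1CC[C@@H](C)C[C@@]12N(C)C(=O)[C@@H]1[C@H]3C(=O)NC(=O)[C@H]3ON12` gives 25.9%;
compound 2 `Cc1cccc(N2C(=O)[C@H]3[C@H](ON4[C@@H]3C(=O)N(C)[C@@]43C[C@H](C)CC[C@H]3C(C)C)C2=O)c1` gives 25%;
compound 3 `Cc1ccc(N2C(=O)[C@H]3[C@H](ON4[C@@H]3C(=O)N(C)[C@@]43C[C@H](C)CC[C@H]3C(C)C)C2=O)c(C)c1` gives 51%.

Compound 3 stands highest of the three, and both of its steps lie beyond the scatter: a number 25.1 percentage points higher from compound 1 to compound 3 (beyond the scatter) and a number 26 percentage points higher from compound 2 to compound 3 (beyond the scatter). By contrast a number 0.9 percentage points lower from compound 1 to compound 2 (within the scatter), so compound 1 and compound 2 cannot be told apart.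

Compound 4 `CC(C)[C@@H]1CC[C@@H](C)C[C@@]12N(C)C(=O)[C@@H]1[C@H]3C(=O)N(c4ccc5ccccc5c4)C(=O)[C@H]3ON12` is the next compound, and it differs from compound 3 in one place: naphthalen-2-yl in place of 2,4-dimethylphenyl on an amide-type nitrogen in a ring.

The measured steps show that placing an aromatic group on this nitrogen can leave the read-out unchanged, as with compound 2, or raise it modestly, as with compound 3. Among the measured compounds shown here, no measured step shows a group with two aromatic rings at this position, so the direction for compound 4 is uncertain. The expectation is that compound 4 lands between the levels of compound 1 and compound 3, with a step of a number 11 percentage points lower from compound 3 to compound 4 (beyond the scatter) expected, most likely not beyond the scatter. Compound 4 is therefore estimated at 40%, within a range from 18% to 62%.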

Compound 4, a percentage reported as activity, at one concentration (the size of the read-out at that concentration, not a potency): 24.5%
Beside the measured number, compound 4's estimate is 15.5 percentage points above it; the range from low to high includes it.
By their numbers in this assay, from the lowest: compounds 4, 2 and 1 (each within the scatter of the next); then compound 3.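

In this assay, naphthalen-2-yl on this amide-type nitrogen brings no gain: the change gives a number 26.5 percentage points lower from compound 3 to compound 4 (beyond the scatter) and also a number 0.5 percentage points lower from compound 2 to compound 4 (within the scatter) and a number 1.4 percentage points lower from compound 1 to compound 4 (within the scatter). So a second aromatic ring and more carbon do not by themselves lift the read-out, and among the four compounds only the one with 2,4-dimethylphenyl stands clear of the rest. Nothing available explains why this one group stands apart.

On these data alone, it remains open whether the rise seen with 2,4-dimethylphenyl needs both methyl groups, or whether a single methyl group in another place on the phenyl ring would give it too. Also open, as far as these compounds go, is what a non-aromatic group such as cyclohexyl, or a pyridinyl ring, would give on this nitrogen.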